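Methyl on the pyrrolidine ring of the kinase series

A few compounds are considered here, and "the series" means these few. Any claim that something is new, unique, unknown or untested is made for them only; others in the source may bear on it.

Two compounds carry measurements so far. Compound 1 `Cn1c(N2CCCC2)c(C#N)c2c(N)ncnc21` gives 1480 nM in an assay on isolated protein for inhibition of Leucine-rich repeat serine/threonine-protein kinase 2 (Homo sapiens), read by TR-FRET and LanthaScreen, with stated times of 50 min and 30 min, in the presence of a further agent that is not named here (on this read-out lower numbers stand for stronger inhibition and higher numbers for weaker inhibition), the higher of the two numbers. For the measured compounds named here, compound 2 `Cc1nn(CC(C)(C)O)cc1Nc1nc(N)c2c(C#N)c(N3CCC[C@H]3C)n(C)c2n1`, which carries a substituted aminopyrazole on the shared core and a 2-methylpyrrolidin-1-yl group, gives 49 nM in this assay; no single-point step connects it to compound 1, and the gap between the two values lies beyond the scatter.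

Compound 3 `C[C@H]1CCCN1c1c(C#N)c2c(N)ncnc2n1C` awaits measurement in this assay. The change from compound 1 is methyl in place of hydrogen on a saturated ring carbon. The same 2-methylpyrrolidin-1-yl group is present in compound 2, but that compound also differs elsewhere, so the methyl alone cannot be credited with its value. A modest step toward a lower number is expected, within or just beyond the scatter. The estimate for compound 3 is 600 nM, with a range of 250 nM to 1500 nM, and the expected step is a 2.5-fold lower number from compound 1 to compound 3 (0.39 log units; beyond the scatter).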

Compound 3, half-maximal inhibitory concentration: 5660 nM
Compound 3: the middle estimate sits 9.4-fold (0.97 log units) below what was measured, outside the stated range (above it).
By their numbers in this assay, from the lowest: compound 2; then compound 1; then compound 3.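

In this assay, the change from pyrrolidin-1-yl to 2-methylpyrrolidin-1-yl gives a 3.8-fold higher number from compound 1 to compound 3 (0.58 log units; beyond the scatter), so without the substituted aminopyrazole, methyl on this saturated ring carbon next to the ring nitrogen costs inhibition rather than adding to it. For the compounds shown here, this is the first single-change reading at this position, and it shows that one added carbon here is enough to move the number beyond the scatter. Nothing at hand accounts for the direction of this step.

Open, going by these compounds, is whether the step carries over to compounds with the substituted aminopyrazole, where compound 2, with the same 2-methylpyrrolidin-1-yl group, gives 49 nM. Also open, on these data alone, is how this ring carbon responds to the opposite methyl stereoisomer or to a larger group such as ethyl or hydroxymethyl.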